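A few compounds are considered here, and "the series" means these few. Any claim that something is new, unique, unknown or untested is made for them only; others in the source may bear on it.

In a functional assay on BEL-7404 cells (Homo sapiens) for cytotoxicity, read by MTT assay, with a stated time of 72 h (on this read-out lower numbers stand for stronger inhibition and higher numbers for weaker inhibition), compound 1 (`CCN(CC)CC#Cc1ccnc2ccc(-c3cnc(OC)c(NS(=O)(=O)c4ccc(F)cc4F)c3)cc12`) gives 300 nM, the lower of the two numbers available, while compound 2 (`COc1ncc(-c2ccc3nccc(C#CCN(C4CCCCC4)C4CCCCC4)c3c2)cc1NS(=O)(=O)c1ccc(F)cc1F`) gives 6100 nM, a gap beyond the usual scatter. Compound 3 (`COc1ncc(-c2ccc3nccc(C#CCN4CCC(C)CC4)c3c2)cc1NS(=O)(=O)c1ccc(F)cc1F`) is not yet measured. Relative to compound 1 it carries the change (4-methylpiperidin-1-yl in place of diethylamino on a saturated chain carbon bound to a triple-bonded carbon), with 4-methylpiperidin-1-yl in place of diethylamino on a saturated chain carbon bound to a triple-bonded carbon. Within the data shown here, no measured step isolates a single change, so the expectation rests only on compound 1 at 300 nM and compound 2 at 6100 nM. A small move toward weaker inhibition is expected, close to the size of the scatter, with compound 3 staying nearer the lower of those two numbers. The expected step is a 1.8-fold higher number from compound 1 to compound 3 (0.26 log units; within the scatter). In this assay the estimate for compound 3 is 550 nM, with an expected range of 150 nM to 2000 nM.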

Compound 3, half-maximal inhibitory concentration: 1550 nM
The estimate for compound 3 lay 2.8-fold (0.45 log units) below the measured number; low and high end bracket the measured number.
By their numbers in this assay, from the lowest: compound 1; then compound 3; then compound 2.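

In this assay, the position on a saturated chain carbon bound to a triple-bonded carbon does not tolerate every amine equally: 4-methylpiperidin-1-yl in place of diethylamino gives a 5.2-fold higher number from compound 1 to compound 3 (0.71 log units; beyond the scatter), a step beyond the scatter for a group only modestly larger than diethylamino. With compound 3 at 1550 nM and compound 2 at 6100 nM, the printed numbers place compound 3 between compound 1 and compound 2, so the earlier two-point gap now has an intermediate value. Nothing measured on these compounds bears on the reason for this step.

The compounds shown do not separate the contribution of the ring from that of its methyl group, which an unsubstituted piperidin-1-yl would address. On these data alone, whether a smaller amine such as dimethylamino, or a ring with a second hetero atom such as morpholin-4-yl, matches or improves on compound 1 remains open.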